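A few compounds are considered here, and "the series" means these few. Any claim that something is new, unique, unknown or untested is made for them only; others in the source may bear on it.

Compound 1 `C/C(=N\Nc1nc(-c2ccccc2)cs1)c1sc(C)nc1C`: in a toxicity assay on THP-1 cells (Homo sapiens) for cytotoxicity, read by MTT assay (on this read-out lower numbers stand for stronger inhibition of growth and higher numbers for weaker inhibition of growth), compound 1 gives > 100 ug/mL, a limit of the assay.
Compound 2 `C/C(=N\Nc1nc(-c2ccc(F)cc2)cs1)c1sc(C)nc1C`: in this assay compound 2 gives > 100 ug/mL, again a limit.
Compound 3 `C/C(=N\Nc1nc(-c2ccccc2)cs1)c1sc(-c2ccccc2)nc1C`: in this assay compound 3 gives > 100 ug/mL, also a limit.

Compound 3 thus stands at the limit of > 100 ug/mL in this assay, at which 3 of the 3 values shown sit; no measured number places it relative to the other two. Compound 4 `C/C(=N\Nc1nc(-c2ccc(F)cc2)cs1)c1sc(-c2ccccc2)nc1C` differs from compound 3 by fluoro in place of hydrogen on an aromatic carbon. Among the measured compounds shown here, the same change has been measured once, as a step that the two limits leave unreadable from compound 1 to compound 2; the only other measured step, a step that the two limits leave unreadable from compound 1 to compound 3, is equally unreadable. Neither step gives a size or a direction, so no change beyond the scatter is expected, and the step that the limit leaves unreadable from compound 3 to compound 4 is the estimate. Compound 4 is accordingly expected to give about 150 ug/mL, within 70 ug/mL to 400 ug/mL, and is most likely to be reported once more only as a limit in this assay.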

Compound 4, concentration for 50% growth inhibition: > 100 ug/mL
Compound 4: no number, only a limit (the forecaster's own chance of this, stated with the estimate: 85%); the middle value is on the limit's open side.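

In this assay compound 4 gives only a limit, so neither its step from compound 3 nor its step from compound 2 can be read. Whether either replacement shifts growth inhibition at all stays open: the limit of > 100 ug/mL in this assay, at which 4 of the 4 values shown sit.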